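Changing the aryl group on a compound at the limit

The source may hold more compounds than are shown below. What is called first, only, known or untested is meant among the compounds shown, and "the series" means these compounds.

Measured in a functional assay on MDA-MB-231 cells (Homo sapiens) for antiproliferative activity, read by MTT assay, with a stated time of 24 h; a higher number here means a weaker inhibitor, a lower number a stronger inhibitor:
Compound 1 `O=C(NNc1ccccc1Cl)c1cccc(NS(=O)(=O)c2cnc(O)nc2O)c1`: 2090 nM
Compound 2 `O=C(NNc1cccc(Cl)c1)c1cccc(NS(=O)(=O)c2cnc(O)nc2O)c1`: 7760 nM
Compound 3 `Cc1ccccc1NNC(=O)c1ccccc1NS(=O)(=O)c1cnc(O)nc1O`: > 20000 nM (a limit, not a number)

Compound 3 gives only a limit, so its place is the limit of > 20000 nM in this assay, at which 1 of the 3 values shown sits, and no exact figure exists. Compound 4 `O=C(NNc1cccc(Cl)c1)c1ccccc1NS(=O)(=O)c1cnc(O)nc1O` keeps the core of compound 3 and changes one group: 3-chlorophenyl in place of 2-methylphenyl on an amine nitrogen. Among the measured compounds shown here, the only measured step, a 3.7-fold higher number from compound 1 to compound 2 (0.57 log units; beyond the scatter), is a modest one on a different core, and it does not replace methyl with chlorine. Compound 2 carries the same 3-chlorophenyl and gives 7760 nM on that other core. A modest move to a lower number is therefore expected in this assay, though a second limit remains possible. The estimated change is an at least 1.5-fold lower number from compound 3 to compound 4 (0.18 log units; that floor lies within the scatter) and is only rough. For compound 4 the expected value is 13000 nM, with an estimated range from 5000 nM to 30000 nM as its ends.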

Compound 4, half-maximal inhibitory concentration: 11800 nM
The estimate for compound 4 lay 1.1-fold (0.04 log units) above the measured number; the range from low to high includes it.
By their numbers in this assay, from the lowest: compound 1; then compounds 2 and 4 (each within the scatter of the next). At a limit, above all of these: compound 3.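

In this assay, 3-chlorophenyl in place of 2-methylphenyl on the amine nitrogen turns a limit into a measured value, with an at least 1.6-fold lower number from compound 3 to compound 4 (0.22 log units; that floor lies within the scatter). Compound 3 gives only a limit, not a number: the limit of > 20000 nM in this assay, at which 1 of the 4 values shown sits.

From the compounds shown here alone, the step is therefore a floor, its true size is unknown, and it changes both the group and its numbered place on the ring, so neither change can be credited alone. Going by these compounds, it remains open how 3-methylphenyl or 2-chlorophenyl would behave on this core, and whether a phenyl carrying an amine or a carboxylic acid would give a lower number.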